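Fluoro on the dimethylphenyl ring across two imidazole cores

This account rests on a few compounds, and the source may have more. Where it says the series, first, only, none or still open, it means among the compounds named here.

Measured so far in an assay on microsomes from liver for inhibition of 3-hydroxy-3-methylglutaryl-coenzyme A reductase (Rattus norvegicus); a higher number here means a weaker inhibitor, a lower number a stronger inhibitor:
compound 1 `Cc1cc(C)cc(-c2nc(C(F)(F)F)n(CC[C@@H](O)C[C@@H](O)CC(=O)O)c2-c2ccc(F)cc2)c1` gives 24 nM
compound 2 `Cc1cc(-c2nc(C(F)(F)F)n(CC[C@@H](O)C[C@@H](O)CC(=O)O)c2-c2ccc(F)cc2)cc(C)c1F` gives 32 nM
compound 3 `Cc1cc(C)cc(-c2c(-c3ccc(F)cc3)nc(C(F)(F)F)n2CC[C@@H](O)C[C@@H](O)CC(=O)O)c1` gives 38 nM

Compounds 1 and 2 share one core; compound 3 is built from the same atoms joined differently, and the difference between the two cores is not broken down here. All three values sit within the usual scatter of one another, so no order among them is claimed.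

The change from compound 1 to compound 2 is fluoro in place of hydrogen on an aromatic carbon, and in this assay it made a 1.3-fold higher number from compound 1 to compound 2 (0.12 log units; within the scatter).

Compound 4 `Cc1cc(-c2c(-c3ccc(F)cc3)nc(C(F)(F)F)n2CC[C@@H](O)C[C@@H](O)CC(=O)O)cc(C)c1F` has not yet been measured. It differs from compound 3 by fluoro in place of hydrogen on an aromatic carbon. The place of the change is described in the same words as for the pair above, so this is the same change, applied to the other core.

For compound 4 in this assay the expected step from compound 3 is a 1.3-fold higher number from compound 3 to compound 4 (0.10 log units; within the scatter), a small step because it rests on a 1.3-fold higher number from compound 1 to compound 2 (0.12 log units; within the scatter), which itself stayed within the scatter. Compound 4 is therefore estimated at 48 nM, with a likely range from 24 nM to 95 nM.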

Compound 4, half-maximal inhibitory concentration: 31 nM
For compound 4 the middle estimate is 1.5-fold (0.19 log units) above the measured one; measured number inside the range.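

In this assay, the change from 3,5-dimethylphenyl to 4-fluoro-3,5-dimethylphenyl gave a 1.2-fold lower number from compound 3 to compound 4 (0.09 log units; within the scatter). Carried from the core of compound 1 to the core of compound 3, the fluoro change shows no difference between its two steps, so in this small set the step on one core serves as a fair guide to the step on the other: the same change on two cores in this assay, a 1.3-fold higher number (0.12 log units; within the scatter) from compound 1 to compound 2 and a 1.2-fold lower number (0.09 log units; within the scatter) from compound 3 to compound 4, 1.6-fold (0.21 log units) apart, within the scatter of two such steps. This does not show that the change has an effect on either core, since both steps stay within the scatter, and agreement between two small steps in one assay says little about how a larger step would carry over.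

As far as these compounds go, whether chloro, methoxy or an amine in place of that fluoro would give a step beyond the scatter, and whether such a step would match on both cores, stays open. From the compounds shown here alone, all four compounds also keep trifluoromethyl, so the size of the fluoro step with a methyl group there is unknown.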